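The source may hold more compounds than are shown below. What is called first, only, known or untested is meant among the compounds shown, and "the series" means these compounds.

Of the compounds shown here, three of one shared core have been tested in a functional assay (muscle tissue) with Cavia porcellus as the target; a higher number here means that more compound is needed for the effect, a lower number that less compound is needed. Compound 1, with the structure `COC(=O)C1=C(C)N=C(C)/C(=C(\O)OC)C1c1cccc([N+](C)(C)C)c1`, gives 50100 nM in this assay, the highest of the three numbers. Compound 2, `COC(=O)C1=C(C)N=C(C)/C(=C(\O)OC)C1c1cccc(Cl)c1Cl`, gives 19.1 nM, and compound 3, `COC(=O)C1=C(C)N=C(C)/C(=C(\O)OC)C1c1ccccc1C`, gives 6.03 nM; both values lie far below that of compound 1, so compound 1 stands apart as the compound that needs by far the most material for the effect.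

The next compound, compound 4, has the structure `COC(=O)C1=C(C)N=C(C)/C(=C(\O)OC)C1c1cccc(C(F)(F)F)c1`. It differs from compound 1 in a single place: a group of 4 heavy atoms (1 carbon, 3 fluorine; no ring) in place of a group of 4 heavy atoms (3 carbon, 1 nitrogen; no ring), on an aromatic carbon. The group that leaves carries a net charge; the trifluoromethyl that enters does not.

Among the measured compounds shown here, only one measured step, a 3.2-fold lower number from compound 2 to compound 3 (0.50 log units; beyond the scatter), compares two groups on the aromatic ring, and it is modest. For the measured compounds named here, no measured step swaps a group with a net charge for one without, so the nearest guide is the gap between compound 1 and the two uncharged compounds 2 and 3. Because compound 2 gives 19.1 nM and compound 3 gives 6.03 nM, a step towards numbers of that size is expected, namely a 2500-fold lower number from compound 1 to compound 4 (3.40 log units; beyond the scatter). Compound 4 is therefore estimated at 20 nM, with a range from 3 nM to 200 nM.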

Compound 4, half-maximal effective concentration: 74.1 nM
Compound 4: the middle estimate sits 3.7-fold (0.57 log units) below what was measured; measured number inside the range.
By their numbers in this assay, from the lowest: compound 3; then compound 2; then compound 4; then compound 1.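

In this assay, putting trifluoromethyl in place of the group with a net charge, on this aromatic carbon, gives a 680-fold lower number from compound 1 to compound 4 (2.83 log units; beyond the scatter). Among the compounds shown here, the earlier compounds offered no pair that differed only at this place, so this is the first direct sign that this single group, and not the shared core, accounts for a large part of the high number of compound 1. Nothing measured here explains why the change has this size.

The compounds shown leave open whether the net charge itself or some other difference between the two groups matters, as this one pair changes the charge and the atoms together and the two cannot be separated. A tert-butyl group, built of carbon and hydrogen without a net charge, or an amine such as dimethylamino on the same aromatic carbon would help to pull these apart, and a plain hydrogen there would show what trifluoromethyl itself adds.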